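From propylcarbonyl to methoxymethyl: compound 3 and compound 4

The source may hold more compounds than are shown below. What is called first, only, known or untested is meant among the compounds shown, and "the series" means these compounds.

Compound 1 `CC(=O)O[C@@H]1/C=C/[C@@](C)(CCC=C(C)C)C/C=C(/CO)C(=O)/C=C/[C@@]1(C)O` gives 9870 nM
Compound 2 `CC(C)=CCC[C@]1(C)/C=C/[C@@H](OC(=O)C(C)C)[C@](C)(O)/C=C/C(=O)/C(CO)=C\C1` gives 10400 nM
Compound 3 `CCCC(=O)O[C@@H]1/C=C/[C@@](C)(CCC=C(C)C)C/C=C(/CO)C(=O)/C=C/[C@@]1(C)O` gives 7810 nM

These values come from a functional assay on SMMC-7721 cells (Homo sapiens) for antiproliferative activity, read by MTT assay, with a stated time of 48 h; on this read-out lower numbers stand for stronger inhibition and higher numbers for weaker inhibition. Compound 3 is not separated from the other two compounds, with a 1.3-fold lower number from compound 1 to compound 3 (0.10 log units; within the scatter) and a 1.3-fold lower number from compound 2 to compound 3 (0.12 log units; within the scatter). The next change leads to compound 4 `COCO[C@@H]1/C=C/[C@@](C)(CCC=C(C)C)C/C=C(/CO)C(=O)/C=C/[C@@]1(C)O` and is methoxymethyl in place of propylcarbonyl on an oxygen on a saturated carbon. The nearest evidence is those two steps together with a 1.1-fold higher number from compound 1 to compound 2 (0.02 log units; within the scatter). All three alter only the group on the carbonyl carbon, and all stay within the scatter. None of them removes the carbonyl, as this change does, so the series gives no direct measure of it and the range must stay wide. No step beyond the scatter is expected in this assay, and the direction is uncertain. The estimated step is a 1.3-fold higher number from compound 3 to compound 4 (0.11 log units; within the scatter). The estimate for compound 4 is 10000 nM, with an expected range from 4500 nM to 22000 nM.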

Compound 4, half-maximal inhibitory concentration: > 40000 nM
Compound 4 was reported as a limit; the forecaster's own chance of this, stated with the estimate: 10%; middle value at least 4.0-fold (0.60 log units) from the limit.
By their numbers in this assay, from the lowest: compounds 3, 1 and 2 (each within the scatter of the next). At a limit, above all of these: compound 4.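

Compound 4 is reported in this assay only as a limit: the limit of > 40000 nM in this assay, at which 1 of the 4 values shown sits. Going by these compounds alone, exchanging the group on an oxygen on a saturated carbon for methoxymethyl gives the first steps beyond the scatter: an at least 5.1-fold higher number from compound 3 to compound 4 (0.70 log units; beyond the scatter), an at least 3.8-fold higher number from compound 2 to compound 4 (0.58 log units; beyond the scatter) and an at least 4.0-fold higher number from compound 1 to compound 4 (0.60 log units; beyond the scatter). Compounds 1, 2 and 3, which carry acetyl, isopropylcarbonyl and propylcarbonyl there, lie within the scatter of one another, so variation on the carbonyl carbon showed little, while compound 4, the only one lacking that carbonyl, stands apart from all three.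

The limit leaves the full size of these steps open. On these data alone, whether the shift follows the loss of the carbonyl or the methoxymethyl group itself also stays open, and a free hydroxyl, a methyl ether or a carbamate on that oxygen would bear on this.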